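Phenyl added two bonds from the carbonyl on a thiophene amide

This account rests on a few compounds, and the source may have more. Where it says the series, first, only, none or still open, it means among the compounds named here.

Compound 1, with the structure `CCC(=O)Nc1sc2c(c1C#N)CCCC2`, is the weakest of the three measured compounds. In a functional assay on RKE cells for antagonist activity at Vasoactive intestinal polypeptide receptor 1 (Rattus norvegicus), read by HTRF and cAMP accumulation, with stated times of 10 min and 30 min (a lower number here means a stronger inhibitor, a higher number a weaker inhibitor), compound 1 gives 12000 nM, the highest of the three numbers. Compound 2 `N#Cc1c(NC(=O)C2CCC2)sc2c1CCCC2` gives 1800 nM in this assay, and compound 3 `N#Cc1c(NC(=O)C2CCCC2)sc2c1CCCC2` gives 470 nM. Both lie beyond the scatter from compound 1: a 6.7-fold lower number from compound 1 to compound 2 (0.82 log units; beyond the scatter) and a 26-fold lower number from compound 1 to compound 3 (1.41 log units; beyond the scatter). Between the two rings, a 3.8-fold lower number from compound 2 to compound 3 (0.58 log units; beyond the scatter).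

Compound 4 has the structure `N#Cc1c(NC(=O)CCc2ccccc2)sc2c1CCCC2`. It differs from compound 1 in one place: phenyl in place of hydrogen on a saturated chain carbon, two bonds along the chain from a carbonyl carbon. The chain on the carbonyl carbon is kept, and a phenyl is attached to its far end.

Among the compounds with values here, none of the measured steps adds a phenyl, so no step matches this change exactly. What they do show is that every enlargement of the group on the carbonyl carbon, from ethyl to cyclobutyl and to cyclopentyl, lowered the number beyond the scatter. The change to compound 4 also adds to that group. A lower number is therefore expected, of a size between those seen, as an 8.0-fold lower number from compound 1 to compound 4 (0.90 log units; beyond the scatter). The estimate for compound 4 is 1500 nM, within a range from 400 nM to 6000 nM.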

Compound 4, half-maximal inhibitory concentration: 290 nM
Estimate against measurement, compound 4: 5.2-fold (0.71 log units) above; measured number below the stated range.
By their numbers in this assay, from the lowest: compounds 4 and 3 (each within the scatter of the next); then compound 2; then compound 1.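

In this assay, a phenyl at the far end of the chain on the carbonyl carbon is clearly tolerated and gives a large gain, a 41-fold lower number from compound 1 to compound 4 (1.62 log units; beyond the scatter), showing that the group here need not be a saturated ring attached directly to the carbonyl carbon, as in the earlier improved compounds. Compound 4 and compound 3 lie within the scatter of each other, so this open chain ending in an aromatic ring and the compact cyclopentyl cannot be separated by their numbers, even though the two groups differ clearly in shape. Nothing available here explains why adding the phenyl has this effect.

The compounds shown leave open whether the length of the chain matters, since a shorter or longer chain carrying the same phenyl would be needed to test this. They also leave open whether the phenyl itself can be changed, for example by adding a fluorine, an amine or a carboxylic acid to the ring, and whether such a group would keep the gain seen with compound 4.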